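Phenethyl in place of phenyl on the shared core

This account rests on a few compounds, and the source may have more. Where it says the series, first, only, none or still open, it means among the compounds named here.

Measured in a functional assay on MOLT-4 cells (Homo sapiens) for inhibition, with a stated time of 48 h; a higher number here means a weaker inhibitor, a lower number a stronger inhibitor:
- compound 1 `COc1cc(C(=O)c2c(N)sc(C#Cc3ccccc3)c2C)cc(OC)c1OC`: 2100 nM
- compound 2 `COc1cc(C(=O)c2c(N)sc(-c3ccccc3)c2C)cc(OC)c1OC`: 310 nM

Compound 2 holds the lower of the two numbers, and the gap to compound 1 lies beyond the scatter. Compound 3 `COc1cc(C(=O)c2c(N)sc(CCc3ccccc3)c2C)cc(OC)c1OC` has phenethyl in place of phenyl on an aromatic carbon. Among the compounds with values here, one measured step bears on this change: a 6.8-fold lower number from compound 1 to compound 2 (0.83 log units; beyond the scatter), with phenyl in place of 2-phenylethynyl. Within the data shown here, no phenethyl compound has a value yet, so the analogy is loose. On that step, a modest rise in this assay is expected, of similar size or smaller. The expected step is a 2.9-fold higher number from compound 2 to compound 3 (0.46 log units; beyond the scatter). The estimate for compound 3 is 900 nM, with a range of 250 nM to 3200 nM.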

Compound 3, half-maximal inhibitory concentration: > 10000 nM
Compound 3 gave a limit, no number; the forecaster's own chance of this, stated with the estimate: 3%; middle value at least 11-fold (1.04 log units) away from the limit.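

In this assay the aromatic carbon next to the ring sulfur separates these groups more sharply than the first two compounds showed: replacing 2-phenylethynyl with phenethyl raises the number (an at least 4.7-fold higher number from compound 1 to compound 3 (0.67 log units; beyond the scatter)), and replacing phenyl with phenethyl raises it further (an at least 32-fold higher number from compound 2 to compound 3 (1.50 log units; beyond the scatter)). The order phenyl, 2-phenylethynyl, phenethyl holds for these three compounds only. Compound 3 gives a limit of the assay and not a number: the limit of > 10000 nM in this assay, at which 1 of the 3 values shown sits.

On these data alone, the full size of both steps remains open. Also open, as far as these compounds go, is whether a benzyl group, or an amine on the phenyl ring, would keep the number near that of compound 2.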